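From 4-bromophenyl to 3-methoxyphenyl on an aromatic nitrogen

The source may report more compounds than this note shows. Statements on the series, on what has been measured and on what is new or still open speak of the compounds shown alone.

Of the compounds shown here, two with a shared core have so far been measured in an ADME assay on cells (Fibroblast, Homo sapiens) for cytotoxicity, read by cell counting, with a stated time of 48 h; on this read-out lower numbers stand for stronger inhibition and higher numbers for weaker inhibition. Compound 1 `COc1ccccc1-n1cc(COc2cccc3cnc(Nc4cccc(Cl)c4)nc23)nn1` gives > 25000 nM, which is a limit of the assay and not a number. Compound 2 `Clc1cccc(Nc2ncc3cccc(OCc4cn(-c5ccc(Br)cc5)nn4)c3n2)c1` gives > 25000 nM, which is also a limit. Compound 2 therefore has no exact number, and the record so far is the limit of > 25000 nM in this assay, at which 2 of the 2 values shown sit.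

Compound 3 `COc1cccc(-n2cc(COc3cccc4cnc(Nc5cccc(Cl)c5)nc34)nn2)c1` changes one group of compound 2: 3-methoxyphenyl in place of 4-bromophenyl on an aromatic nitrogen. Here, 3-methoxyphenyl takes the place of 4-bromophenyl on an aromatic nitrogen. Among the measured compounds shown here, one measured step bears on this change, a step that the two limits leave unreadable from compound 1 to compound 2, where 4-bromophenyl takes the place of 2-methoxyphenyl, also on an aromatic nitrogen. Its size cannot be read, so it offers no measured size to carry over. Compound 1, which also carries a methoxyphenyl group, gives > 25000 nM, again a limit. No step beyond the usual scatter, in either direction, is therefore expected in this assay. The estimated step is a step that the limit leaves unreadable from compound 2 to compound 3. For compound 3 the expected value is 30000 nM, with an estimated range from 15000 nM to 60000 nM.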

Compound 3, half-maximal inhibitory concentration: 18000 nM
For compound 3 the middle estimate is 1.7-fold (0.22 log units) above the measured one; the measured number falls inside the stated range.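

With 3-methoxyphenyl on the aromatic nitrogen, compound 3 gives the first exact number among these compounds in this assay, so a group at this position can bring the read-out inside the measurable range. Set against 4-bromophenyl, the change is an at least 1.3-fold lower number from compound 2 to compound 3 (0.14 log units; that floor lies within the scatter), and set against 2-methoxyphenyl, it is an at least 1.3-fold lower number from compound 1 to compound 3 (0.14 log units; that floor lies within the scatter); each of these is only a floor, and each floor lies within the scatter, so neither establishes a real change, although the true steps could be larger. Any comparison at this position therefore still rests largely on one limit: the limit of > 25000 nM in this assay, at which 2 of the 3 values shown sit.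

The compounds shown leave open how far the number can fall at this position, and whether any aryl group here can give a step clearly beyond the scatter. They also leave open what 4-methoxyphenyl would give, and what happens when an amine or a carboxylic acid is placed on the phenyl ring, or when a longer chain takes the place of that ring on the aromatic nitrogen.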